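Cyclobutyl amide in place of hydroxycyclohexyl on the aminopyridine core

This account rests on a few compounds, and the source may have more. Where it says the series, first, only, none or still open, it means among the compounds named here.

Measured compounds:
compound 1, `N#Cc1cnc(NCc2cnccc2C(F)(F)F)cc1N[C@H]1CC[C@@H](O)CC1`, 100 nM
compound 2, `N#Cc1cnc(NCc2ccccc2)cc1N[C@H]1CC[C@@H](O)CC1`, 7000 nM

In an assay on isolated protein for inhibition of protein kinase C theta type (Homo sapiens), read by TR-FRET, with a stated time of 2 h (a higher number here means a weaker inhibitor, a lower number a stronger inhibitor), compound 1 gives 100 nM, the lowest of the two numbers in hand. Compound 2, which carries a plain benzyl in place of the trifluoromethyl-bearing pyridylmethyl, gives 7000 nM, a far higher number and well beyond the scatter. For the measured compounds named here, no pair of compounds differing in one place has been measured, so no single-point step is known.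

Compound 3, `CC1(C)[C@H](Nc2cc(NCc3cnccc3C(F)(F)F)ncc2C#N)C[C@H]1C(N)=O`, has not yet been measured. It keeps the aminopyridine core and the trifluoromethyl-bearing pyridylmethyl of compound 1 and changes only the group on the other nitrogen: 3-carbamoyl-2,2-dimethylcyclobutyl in place of 4-hydroxycyclohexyl on a nitrogen on an aromatic ring. Both groups carry one hydrogen-bond donor and one hydrogen-bond acceptor, and nothing measured here bears on a cyclobutyl amide of this kind, so the direction cannot be anchored to any shown pair. The step from compound 1 to compound 3 in this assay is expected to be modest, a 2.0-fold higher number from compound 1 to compound 3 (0.30 log units; within the scatter), with a weaker result somewhat more likely than a stronger one. For compound 3 in this assay the estimate is 200 nM, within a range of 40 nM to 1000 nM.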

Compound 3, half-maximal inhibitory concentration: 140 nM
For compound 3 the middle estimate is 1.4-fold (0.15 log units) above the measured one; the range from low to high includes it.
By their numbers in this assay, from the lowest: compounds 1 and 3 (each within the scatter of the next); then compound 2.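

In this assay, for the compounds shown here, the step of a 1.4-fold higher number from compound 1 to compound 3 (0.15 log units; within the scatter) is the first reading at this position, on a nitrogen on an aromatic ring, since compound 1 and compound 2 both carry 4-hydroxycyclohexyl there. It shows that 3-carbamoyl-2,2-dimethylcyclobutyl can stand in place of 4-hydroxycyclohexyl with no separation beyond the scatter, even though the six-membered ring gives way to a four-membered ring and the group grows from 7 to 9 heavy atoms, while the count of 1 hydrogen-bond donor and 1 hydrogen-bond acceptor stays the same. No supporting measurement is available to explain why the two groups read alike.

The compounds shown do not separate the roles of the carbamoyl, the two methyl groups and the four-membered ring, so a cyclobutyl bearing a carboxylic acid or an aminomethyl group in place of the carbamoyl, or one lacking the two methyl groups, would be the informative comparison. Also open, going by these compounds, is whether 3-carbamoyl-2,2-dimethylcyclobutyl reads the same alongside the plain benzyl of compound 2, and how the other stereoisomers of this cyclobutyl group compare.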